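Swapping the phenylethyl arm for a bromophenyl group

The source may hold more compounds than are shown below. What is called first, only, known or untested is meant among the compounds shown, and "the series" means these compounds.

Compound 1 `COc1cc2c(Nc3cccc([N+](=O)[O-])c3)ncnc2c(OC)c1OC`: 24400 nM
Compound 2 `COc1cc2c(Nc3ccccc3[N+](=O)[O-])ncnc2c(OC)c1OC`: 31200 nM
Compound 3 `COc1cc2c(N[C@@H](C)c3ccccc3)ncnc2c(OC)c1OC`: 10000 nM

All three compounds share one core and differ only in the group attached to a nitrogen on that core. They were tested in a functional assay on PC-3 cells (Homo sapiens) for inhibition, read by MTT assay, with a stated time of 72 h; on this read-out lower numbers stand for stronger inhibition and higher numbers for weaker inhibition. Compound 1 carries a nitrophenyl group and gives 24400 nM; compound 2, also bearing a nitrophenyl group, gives 31200 nM. Compound 3 carries a 1-phenylethyl group and gives 10000 nM, the lowest of the three numbers and thus the strongest inhibition seen here; its gaps to compound 1 and to compound 2 both lie beyond the usual scatter.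

Compound 4 `COc1cc2c(Nc3ccc(Br)cc3)ncnc2c(OC)c1OC` has not yet been measured. (4-bromophenyl in place of 1-phenylethyl on a nitrogen on an aromatic ring). The change removes the stereocentre and returns to a phenyl ring on that nitrogen, as in compound 1 and compound 2, with bromine in place of nitro. Among the compounds with values here, no pair of measured compounds isolates this change. Compound 1 gives 24400 nM and compound 2 gives 31200 nM, both weaker than compound 3. On that basis the step is expected to be a modest loss of potency, a 1.8-fold higher number from compound 3 to compound 4 (0.26 log units; within the scatter), though a result within the scatter would not surprise. Compound 4 is therefore estimated at 18000 nM, within a range from 6000 nM to 50000 nM.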

Compound 4, half-maximal inhibitory concentration: 23400 nM
For compound 4 the middle estimate is 1.3-fold (0.11 log units) below the measured one; the range from low to high includes it.
By their numbers in this assay, from the lowest: compound 3; then compounds 4, 1 and 2 (each within the scatter of the next).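

In this assay, the first step measured at this nitrogen is a 2.3-fold higher number from compound 3 to compound 4 (0.37 log units; beyond the scatter), so trading 1-phenylethyl for 4-bromophenyl costs some inhibition without abolishing it. The new number also places compound 4 within the usual scatter of compound 1 and, through it, in the same band as compound 2, so all three compounds with a substituted phenyl ring on this nitrogen stand apart from compound 3, which remains the strongest of the four, and none of the four goes against that split. The change removes the stereocentre and the carbon chain link and adds a bromine all at once, and nothing shown here separates these parts or explains the loss.

The compounds shown leave open whether the gap belongs to the 1-phenylethyl group as a whole, a question that a plain benzyl group, an unsubstituted phenyl group or the mirror-image form of 1-phenylethyl could help settle. They also leave open whether a quite different arm on this nitrogen, such as a chain ending in an amine or a carboxylic acid, would go beyond compound 3.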